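Removing one methyl from compound 3: expected effect

The source may hold more compounds than are shown below. What is called first, only, known or untested is meant among the compounds shown, and "the series" means these compounds.

The series rests on a shared core. Compound 1 `CCOC(=O)Cn1ncc2c(C)ncn2c1=O` and compound 2 `C=CCn1ncc2cncn2c1=O` differ from compound 3 `C=CCn1ncc2c(C)nc(C)n2c1=O` in more than one place, and compound 4 `C=CCn1ncc2c(C)ncn2c1=O` is the next member, not yet measured. In a functional assay for inhibition, with Homo sapiens as the target (a higher number here means a weaker inhibitor, a lower number a stronger inhibitor), compound 1 gives > 48000 nM, a limit of the assay rather than a number. Compound 2 likewise gives > 48000 nM in this assay, also a limit. Among the compounds with values here, compound 3 is the only member with a number in this assay, at 73000 nM, which places it as a weak inhibitor. The evidence is the limit of > 48000 nM in this assay, at which 2 of the 3 values shown sit. Compound 4 differs from compound 3 by hydrogen in place of methyl on an aromatic carbon. Within the data shown here, no measured pair differs in a single place, so the size of such a step is not known from these data. Because compound 3 stands at 73000 nM, little room for movement is visible in either direction. The expected step for compound 4 is a 1.0-fold lower number from compound 3 to compound 4 (0.02 log units; within the scatter), none beyond the scatter. Compound 4 is estimated at 70000 nM, with a range of 35000 nM to 140000 nM, and a reported limit rather than a number is a likely outcome.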

Compound 4, half-maximal inhibitory concentration: > 48000 nM
Compound 4: a limit, no number; the forecaster's own chance of this, stated with the estimate: 60%; the middle value is on the limit's open side.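

Compound 4 gives a limit rather than a number in this assay, so its steps from compound 1, compound 2 and compound 3 cannot be read. The compounds shown leave open how far any single change on the shared core moves the inhibition, as most values sit at one limit: the limit of > 48000 nM in this assay, at which 3 of the 4 values shown sit.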